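The compounds below may be only part of what the source reports. "The series", "measured", "known", "first", "only" and "open" are said of these compounds alone.

Measured compounds:
- compound 1 `COc1ccccc1/C=c1/[nH]c(=O)/c(=C\c2cccc(Cl)c2Cl)[nH]c1=O`: "not active" (no number reported)
- compound 2 `C=CCn1c(=O)/c(=C\c2cccc(Cl)c2Cl)[nH]c(=O)/c1=C\c1ccccc1OC`: 2100 nM

In a functional assay on MCF7 cells (Homo sapiens) for cytotoxicity, read by CCK-8 assay, with a stated time of 72 h (on this read-out higher numbers stand for weaker inhibition and lower numbers for stronger inhibition), compound 1 gives "not active" (no number reported), so no single number places it on the scale. In this assay compound 2 gives 2100 nM, which is the only numerical result so far. Compound 1 and compound 2 share the same two arylidene arms and differ only in the group on one ring nitrogen, and with no number for compound 1 nothing can be said about the size of that gap.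

Compound 3 `COc1ccccc1/C=c1/[nH]c(=O)/c(=C\c2ccccc2OC)[nH]c1=O` has not yet been measured. It differs from compound 1 by 2-methoxyphenyl in place of 2,3-dichlorophenyl on a double-bonded chain carbon bound to an aromatic carbon, so that both arms of compound 3 carry the same 2-methoxyphenyl group. Among the measured compounds shown here, with compound 1 showing no measurable activity, the expectation is that compound 3 in this assay stays weak as well, with no step clearly beyond the scatter in either direction, and a sizable chance that again only a limit is reported. Compound 3 is estimated at 30000 nM, in a range from 5000 nM to 150000 nM.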

Compound 3, half-maximal inhibitory concentration: "not active" (no number reported)
Compound 3 has no reported number here; the estimate stays without a comparison.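

In this assay, among the compounds shown here, compound 1 gives "not active" (no number reported) and compound 3 gives "not active" (no number reported) so no step between them can be read. No measured evidence bears on this result. These compounds leave open whether 2-methoxyphenyl in place of 2,3-dichlorophenyl changes the potency at all.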